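Chloro in place of cyano on compound 3

The source may hold more compounds than are shown below. What is called first, only, known or untested is meant among the compounds shown, and "the series" means these compounds.

The series shares the core of compound 1 `NC(=O)c1ccccc1C1Cc2nccn2C1` and varies one aromatic substituent. In a physicochemical assay for lipophilicity, at pH 7.4 (on this read-out lower numbers stand for lower lipophilicity and higher numbers for higher lipophilicity), compound 1 stands as "not determined" (no result reported), so it offers no number for comparison. Compound 2 `FC(F)Oc1ccccc1C1Cc2nccn2C1` gives 2.3, and compound 3 `N#Cc1ccccc1C1Cc2nccn2C1` gives 1.3, the lower of the two numbers available.

Compound 4 `Clc1ccccc1C1Cc2nccn2C1` has yet to be measured in this assay. Its structure differs from that of compound 3 by chloro in place of cyano on an aromatic carbon, in words chloro in place of cyano on an aromatic carbon.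

For the measured compounds named here, only one measured step involves the cyano group: a number 1.00 log units lower from compound 2 to compound 3 (beyond the scatter), with cyano in place of difluoromethoxy on an aromatic carbon. There, cyano entering came with a lower number. Here cyano leaves, so a move in the opposite direction is expected, of a broadly similar size and beyond the scatter. Going by the values given here, this is thin support, as no measured compound carries chloro and the comparison rests on a single pair.

The expected rise is estimated as a number 1.00 log units higher from compound 3 to compound 4 (beyond the scatter). The estimate for compound 4 is 2.3, with an expected range of 1.9 to 2.7.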

Compound 4, distribution coefficient: 2.6
Compound 4: middle estimate off by 0.30 log units, on the low side; measured number inside the range.
By their numbers in this assay, from the lowest: compound 3; then compounds 2 and 4 (each within the scatter of the next).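

In this assay this aromatic carbon now has a second measured step out of the cyano compound, a number 1.30 log units higher from compound 3 to compound 4 (beyond the scatter), and this step has the opposite sign to a number 1.00 log units lower from compound 2 to compound 3 (beyond the scatter), so compound 3 stands apart from both other measured compounds by more than the scatter, whether the incoming group is chloro or the outgoing group is difluoromethoxy. The further step, a number 0.30 log units higher from compound 2 to compound 4 (within the scatter), gives no separation between chloro and difluoromethoxy on this read-out, even though the two groups differ in make-up, so among the three numbers available only the cyano compound is distinct. Nothing available explains why cyano sits apart in this way, and no supporting measurement bears on the size of either step.

As far as these compounds go, whether the separation belongs to cyano alone remains open, as an amine, a carboxylic acid or a longer chain on the same aromatic carbon could fall on either side of compound 3 or alongside compounds 2 and 4. The compounds shown also leave open whether the chloro and cyano step keeps its size and sign on any scaffold other than the shared core.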